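The compounds below may be only part of what the source reports. "The series", "measured", "known", "first", "only" and "open" are said of these compounds alone.

Measured in an ADME assay on L02 cells (Homo sapiens) for cytotoxicity, read by MTT assay, with a stated time of 72 h; on this read-out higher numbers stand for weaker inhibition and lower numbers for stronger inhibition:

- Compound 1 `C/C=C/C(=O)Nc1cccc(Oc2nc(Nc3ccn(C)n3)nc3c2CSCC3)c1`: > 50000 nM
- Compound 2 `CC(C)/C=C/C(=O)Nc1cccc(Oc2nc(Nc3ccn(C)n3)nc3c2CSCC3)c1`: > 50000 nM
- Compound 3 `C=C(C)C(=O)Nc1cccc(Oc2nc(Nc3ccn(C)n3)nc3c2CSCC3)c1`: > 50000 nM

Compound 1 reads > 50000 nM, which is a limit of the assay and not a number. It has no measured neighbour with a number, and the series as a whole shows (the limit of > 50000 nM in this assay, at which 3 of the 3 values shown sit).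

Compound 4 `C/C=C/C(=O)Nc1cccc(Oc2nc(Nc3ccc(OC)cc3)nc3c2CSCC3)c1` differs from compound 1 in one place: 4-methoxyphenyl in place of 1-methyl-1H-pyrazol-3-yl on a nitrogen on an aromatic ring. It carries 4-methoxyphenyl in place of 1-methyl-1H-pyrazol-3-yl on a nitrogen on an aromatic ring.

Three measured steps are available: a step that the two limits leave unreadable from compound 1 to compound 2, a step that the two limits leave unreadable from compound 1 to compound 3 and a step that the two limits leave unreadable from compound 2 to compound 3. All three concern the group on the carbonyl carbon, and none touches that nitrogen. None has a readable size, so they offer no direct measure of this change. For the measured compounds named here, they show only that the three compounds share the same limit.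

In this assay, therefore, no step beyond the scatter is expected, and no direction can be argued from these data. The expected change is a number no higher from compound 1 to compound 4 (the limit leaves the size open). A report of only a limit is the likeliest single outcome. For compound 4 the estimate is 50000 nM, with an expected range from 20000 nM to 100000 nM.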

Compound 4, half-maximal inhibitory concentration: > 50000 nM
Compound 4 gave a limit, no number (the forecaster's own chance of this, stated with the estimate: 65%); the middle value sits exactly at the limit.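

In this assay, for the compounds shown here, compound 4 reads > 50000 nM as a limit of the assay and not a number, and with compound 1 also at a limit, no step between compound 1 and compound 4 can be read. The compounds shown leave open how far a change on the carbonyl carbon or on the nitrogen would move the read-out, since all of them share one limit: the limit of > 50000 nM in this assay, at which 4 of the 4 values shown sit.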